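The source may hold more compounds than are shown below. What is called first, only, known or untested is meant among the compounds shown, and "the series" means these compounds.

Among the compounds with values here, compound 1 `CCCCCCNc1nc(SCc2ccc(C(F)(F)F)cc2)nc2ccccc12` is the one compound of this small set with a measured number. In a functional assay on HGC-27 cells (Homo sapiens) for cytotoxicity, read by MTT assay, with a stated time of 72 h (a higher number here means a weaker inhibitor, a lower number a stronger inhibitor), compound 1 gives 23900 nM, a weak effect but a real value. Compound 2 `FC(F)(F)c1ccc(CSc2nc(N3CCCCC3)c3ccccc3n2)cc1`, which carries piperidin-1-yl in place of hexylamino on the shared core, reaches only a limit of the assay, > 50000 nM. Compound 3 `FC(F)(F)c1ccc(CSc2nc(Nc3ccccc3Cl)c3ccccc3n2)cc1`, with 2-chlorophenyl in place of hexyl on the ring nitrogen, also stops at a limit, > 50000 nM. Both changes are therefore read as an at least 2.0-fold higher number from compound 1 to compound 2 (0.32 log units; beyond the scatter) and an at least 2.0-fold higher number from compound 1 to compound 3 (0.32 log units; beyond the scatter). The step that the two limits leave unreadable from compound 2 to compound 3 stays unreadable since both compounds sit at the limit of > 50000 nM in this assay, at which 2 of the 3 values shown sit.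

Compound 4 `FC(F)(F)c1ccc(CSc2nc(Nc3cccc(Cl)c3)c3ccccc3n2)cc1` is not yet measured. It differs from compound 1 by 3-chlorophenyl in place of hexyl on a nitrogen on an aromatic ring. Within the data shown here, the step that bears on it most directly is the one to compound 3, where an aryl group on the same nitrogen gave an at least 2.0-fold higher number from compound 1 to compound 3 (0.32 log units; beyond the scatter). A rise of at least that size in this assay is therefore expected, with a fair chance that only a limit is reported. Compound 4 is expected to give 55000 nM, within 20000 nM to 150000 nM. That estimate means a 2.3-fold higher number from compound 1 to compound 4 (0.36 log units; beyond the scatter).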

Compound 4, half-maximal inhibitory concentration: 19900 nM
Estimate against measurement, compound 4: 2.8-fold (0.44 log units) above, outside the stated range (below it).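

In this assay, an aryl group on this nitrogen does not by itself lose the effect seen with the hexyl chain: 3-chlorophenyl in place of hexyl gives a 1.2-fold lower number from compound 1 to compound 4 (0.08 log units; within the scatter), so the two groups cannot be told apart here. What compound 3 alone could not show is that the particular chlorophenyl group matters, since 3-chlorophenyl in place of 2-chlorophenyl gives an at least 2.5-fold lower number from compound 3 to compound 4 (0.40 log units; beyond the scatter). The same holds against the piperidine compound, where (3-chlorophenyl)amino in place of piperidin-1-yl gives an at least 2.5-fold lower number from compound 2 to compound 4 (0.40 log units; beyond the scatter), and both of these steps are minimum sizes only, with their true sizes out of reach: the limit of > 50000 nM in this assay, at which 2 of the 4 values shown sit.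

Still open, from the compounds shown here alone, is whether the chlorine is needed at all, which a plain phenyl group on the same nitrogen would test, and whether a fluorine atom or a methyl group could stand in its place. Going by these compounds, it is equally open how the effect follows the chain on this nitrogen, since a butyl or an octyl chain would show whether hexyl is a special case or one point on a wider trend.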